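Fluoro on the phenyl of compound 2

The source may report more compounds than this note shows. Statements on the series, on what has been measured and on what is new or still open speak of the compounds shown alone.

In an ADME assay on the whole organism (Rattus norvegicus, strain Sprague-Dawley) for pharmacokinetics, at a dose of 2 mg/kg by the oral route (a higher number here means more compound in the circulation at the dose given, a lower number less compound in the circulation), compound 1 (`NC(=O)c1cc(-c2ccccc2)cc2c(C3CCN(S(=O)(=O)CCCN4CCCC4)CC3)c[nH]c12`) gives 998 ng.h/mL and compound 2 (`NC(=O)c1cc(-c2ccccc2)cc2c(C3CCS(=O)(=O)CC3)c[nH]c12`) gives 904 ng.h/mL as its value, so the two lie within the scatter of each other. Compound 3 (`NC(=O)c1cc(-c2ccc(F)cc2)cc2c(C3CCS(=O)(=O)CC3)c[nH]c12`) carries fluoro in place of hydrogen on an aromatic carbon, para to a large group (fluoro in place of hydrogen on an aromatic carbon), which turns phenyl to 4-fluorophenyl. Within the data shown here, no measured pair shows this change, so the size expected in this assay rests on the change alone: none beyond the scatter. The estimated step (a 1.1-fold higher number from compound 2 to compound 3 (0.04 log units; within the scatter)) stays inside that scatter. Compound 3 is expected at 1000 ng.h/mL (estimated range 450 ng.h/mL to 2200 ng.h/mL).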

Compound 3, area under the concentration-time curve: 1270 ng.h/mL
Beside the measured number, compound 3's estimate is 1.3-fold (0.10 log units) below it, and the stated range covers the measured number.
By their numbers in this assay, from the lowest: compounds 2, 1 and 3 (each within the scatter of the next).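

In this assay, among these compounds, phenyl to 4-fluorophenyl on compound 2 gives a 1.4-fold higher number from compound 2 to compound 3 (0.15 log units; within the scatter), the only reading of this change. On this single pair, fluoro at this place leaves the exposure after oral dosing within the scatter. No measurement at hand bears on a cause for this result.
Open, from the compounds shown here alone, is whether a larger group at the same place, such as methoxy or trifluoromethyl, would give a step beyond the scatter. Also open, going by these compounds, is whether the same fluoro change on compound 1 would give a step of similar size.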